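The source may report more compounds than this note shows. Statements on the series, on what has been measured and on what is new or still open speak of the compounds shown alone.

Working notes on the series. In a functional assay on MCF7 cells (Homo sapiens) for cytotoxicity, read by MTT assay, with a stated time of 48 h (on this read-out lower numbers stand for stronger inhibition and higher numbers for weaker inhibition), compound 1 (`COc1cc(-c2cc(COCc3cn(Cc4cc(-c5ccccc5)cnc4Cl)nn3)on2)cc(OC)c1OC`) gives 68500 nM and compound 2 (`COc1cc(-c2cc(COCc3cn(Cc4cc(-c5ccc(C)cc5)cnc4Cl)nn3)on2)cc(OC)c1OC`) gives 58400 nM. Compound 2 therefore stands level with compound 1 within the scatter, and the two numbers show no order between them.

The next structure is compound 3 (`COc1cc(-c2cc(COCc3cn(Cc4cc(C)cnc4Cl)nn3)on2)cc(OC)c1OC`), which has methyl in place of 4-methylphenyl on an aromatic carbon. Among the measured compounds shown here, only one measured step bears on this, a 1.2-fold lower number from compound 1 to compound 2 (0.07 log units; within the scatter), with methyl in place of hydrogen on an aromatic carbon. That step lies within the scatter, but it only alters the aryl group and does not remove it. For the measured compounds named here, the data hold no compound without that aryl group, so they support no direction for the change, and the range has to stay wide.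

No step beyond the scatter is expected in this assay, and the estimated change is a 1.2-fold higher number from compound 2 to compound 3 (0.08 log units; within the scatter). For compound 3 the expected value is 70000 nM, with an estimated range of 25000 nM to 190000 nM.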

Compound 3, half-maximal inhibitory concentration: 194000 nM
Compound 3: middle estimate off by 2.8-fold (0.44 log units), on the low side, and the stated range ends below it.
By their numbers in this assay, from the lowest: compounds 2 and 1 (each within the scatter of the next); then compound 3.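

In this assay, methyl in place of 4-methylphenyl gives a 3.3-fold higher number from compound 2 to compound 3 (0.52 log units; beyond the scatter), and methyl in place of phenyl gives a 2.8-fold higher number from compound 1 to compound 3 (0.45 log units; beyond the scatter), so at this carbon, para to a chloro group, inhibition is weaker without the aryl group. Among the compounds shown here, the earlier pair showed only that adding a methyl group to that aryl group leaves the number within the scatter, a 1.2-fold lower number from compound 1 to compound 2 (0.07 log units; within the scatter); the new steps show that this position does respond to a change, and that both aryl compounds stand on the stronger side of the methyl compound, though the effect is modest. Nothing available explains the difference between the aryl groups and methyl.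

The compounds shown leave open whether the aromatic ring itself matters or whether any larger group would serve, a question that a cyclohexyl group or a longer chain such as n-butyl at the same carbon would address. They also leave open whether a methoxy group, an amine or a carboxylic acid on the phenyl ring could move the number beyond the scatter, since methyl is the only substituent on that ring here.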